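Replacing Trifluoromethyl with Chloro: Expected Cytotoxicity of Compound 4

The source may report more compounds than this note shows. Statements on the series, on what has been measured and on what is new or still open speak of the compounds shown alone.

Measured compounds:
Compound 1, `Cc1cc(-c2ccccc2C(F)(F)F)cc(C)c1Nc1ccnc(Nc2ccc(C#N)cc2)n1`: 4210 nM
Compound 2, `Cc1cccc(-c2cc(C)c(Nc3ccnc(Nc4ccc(C#N)cc4)n3)c(C)c2)c1`: 3670 nM
Compound 3, `Cc1cc(-c2ccccc2F)cc(C)c1Nc1ccnc(Nc2ccc(C#N)cc2)n1`: 2120 nM

All three were tested in an ADME assay on MT4 cells (Homo sapiens) for cytotoxicity, read by MTT assay, with a stated time of 4 days; a lower number here means that less compound is tolerated, a higher number that more compound is tolerated. Compound 1 shows the highest of the three numbers, yet the step from it to compound 2 is a 1.1-fold lower number from compound 1 to compound 2 (0.06 log units; within the scatter) and the step to compound 3 is a 2.0-fold lower number from compound 1 to compound 3 (0.30 log units; within the scatter); both lie within the scatter, so the three compounds cannot be told apart on these numbers.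

Compound 4 is `Cc1cc(-c2ccccc2Cl)cc(C)c1Nc1ccnc(Nc2ccc(C#N)cc2)n1`. It differs from compound 1 in one place: chloro in place of trifluoromethyl on an aromatic carbon.

Going by the values given here, two measured steps bear on this. The step from compound 1 to compound 3 changes the same group at the same place, with fluoro in place of trifluoromethyl, and gives a 2.0-fold lower number from compound 1 to compound 3 (0.30 log units; within the scatter). The step from compound 1 to compound 2, which replaces the whole 2-(trifluoromethyl)phenyl by 3-methylphenyl, gives a 1.1-fold lower number from compound 1 to compound 2 (0.06 log units; within the scatter). Neither exceeds the scatter, so a change at this place appears to leave this assay largely unmoved.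

The expected step from compound 1 to compound 4 is therefore a 1.2-fold lower number from compound 1 to compound 4 (0.08 log units; within the scatter), nothing beyond the scatter. Compound 4 is estimated at 3500 nM, with a likely range from 1800 nM to 7000 nM.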

Compound 4, half-maximal cytotoxic concentration: 3990 nM
Compound 4: middle estimate off by 1.1-fold (0.06 log units), on the low side, within the range that was stated.
By their numbers in this assay, from the lowest: compounds 3, 2, 4 and 1 (each within the scatter of the next).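

Read in this assay, chloro in place of trifluoromethyl, one heavy atom for four on an aromatic carbon ortho to a large group, gives a 1.1-fold lower number from compound 1 to compound 4 (0.02 log units; within the scatter), so this reduction in heavy atoms at this place does not move the number beyond the scatter. Going by these compounds alone, the two remaining comparisons agree: chloro in place of fluoro gives a 1.9-fold higher number from compound 3 to compound 4 (0.27 log units; within the scatter), and 2-chlorophenyl in place of 3-methylphenyl gives a 1.1-fold higher number from compound 2 to compound 4 (0.04 log units; within the scatter), which leaves compounds 1, 2, 3 and 4 with no step among them that stands clear of the scatter. Nothing measured here offers a reason why this assay stays so flat across these changes.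

The groups shown on this ring are all small and carry no hydrogen-bond donors, so it remains open whether an amine, a carboxylic acid or a longer chain at this place would give a step beyond the scatter. All four compounds also share the nitrile and the rest of the core, so what those parts contribute to the number in this assay cannot be told from them.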